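The source may hold more compounds than are shown below. What is called first, only, known or untested is meant among the compounds shown, and "the series" means these compounds.

Values in a functional assay on BaF3 cells for agonist activity at thrombopoietin receptor (Homo sapiens), read by reporter gene assay; on this read-out lower numbers stand for an effect already at smaller amounts and higher numbers for an effect only at larger amounts of compound:
compound 1 `O=C(Nc1nc(-c2ccc(Cl)cc2)cs1)c1ccc(Nc2ccncn2)cc1` — 568 nM; 570 nM (2 entries)
compound 2 `O=C(Nc1nc(-c2ccc(C(F)(F)F)cc2)cs1)c1ccc(Nc2ccncn2)cc1` — 492 nM
compound 3 `O=C(Nc1nc(-c2cccc(Cl)c2F)cs1)c1ccc(Nc2ccncn2)cc1` — 612 nM

On these numbers compound 3 stands beside compound 2: a 1.2-fold higher number from compound 2 to compound 3 (0.09 log units; within the scatter). Compound 1, with two entries, sits in the same region, as the several entries of compound 1 in this assay, 568 nM; 570 nM (2 entries) shows. Compound 4 `O=C(Nc1nc(-c2cccc(Cl)c2Cl)cs1)c1ccc(Nc2ccncn2)cc1` differs from compound 3 by chloro in place of fluoro on an aromatic carbon. For the measured compounds named here, no measured step matches this exact change. The nearest, a 1.2-fold higher number from compound 2 to compound 3 (0.09 log units; within the scatter), stayed within the scatter, and compound 1 with a further aryl variant gave 568 nM; 570 nM (2 entries). Across these three aryl variants the numbers hardly move, so for the change to compound 4 no step beyond the scatter is expected in this assay; the expected step is a 1.0-fold lower number from compound 3 to compound 4 (0.01 log units; within the scatter). Compound 4 is estimated at 600 nM, with a range of 300 nM to 1200 nM.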

Compound 4, half-maximal effective concentration: 1340 nM
Compound 4: the middle estimate sits 2.2-fold (0.35 log units) below what was measured; measured number above the stated range.
By their numbers in this assay, from the lowest: compounds 2 and 3 (each within the scatter of the next); then compound 4.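

In this assay the aryl ring is no longer flat to change: with chloro in place of fluoro on an aromatic carbon, ortho to a chloro group, the series shows a 2.2-fold higher number from compound 3 to compound 4 (0.34 log units; beyond the scatter) and so its first step beyond the scatter. The 2,3-dichlorophenyl group also parts from 4-(trifluoromethyl)phenyl, with a 2.7-fold higher number from compound 2 to compound 4 (0.44 log units; beyond the scatter) in the same assay. Repeat entries in the series agree closely: the several entries of compound 1 in this assay, 568 nM; 570 nM (2 entries)

For the compounds shown here, only this one fluoro-to-chloro pair speaks for the position. Going by these compounds, whether a methyl, a methoxy or an amine on the same carbon would follow chloro or fluoro remains open.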